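The source may report more compounds than this note shows. Statements on the series, on what has been measured and on what is new or still open speak of the compounds shown alone.

Measured so far in an ADME assay on Raji cells (Homo sapiens) for cytotoxicity, with a stated time of 72 h; on this read-out higher numbers stand for an effect only at larger amounts of compound and lower numbers for an effect already at smaller amounts:
- compound 1 `COc1ccc(-c2nc3ccccc3o2)cc1NC(=O)c1cc([N+](=O)[O-])ccc1Cl`: > 25000 nM
- compound 2 `O=C(Nc1nc(-c2cccc(F)c2)cs1)c1cc([N+](=O)[O-])ccc1Cl`: 11000 nM

Compound 1 gives the reading > 25000 nM, which is a limit of the assay and not a number. Compound 2 gives a true number, 11000 nM.

Compound 3 `COc1ccc(-c2nc3ccccc3s2)cc1NC(=O)c1cc([N+](=O)[O-])ccc1Cl` keeps the core of compound 1 and changes one group: 1,3-benzothiazol-2-yl in place of 1,3-benzoxazol-2-yl on an aromatic carbon. In words, 1,3-benzothiazol-2-yl stands in place of 1,3-benzoxazol-2-yl on an aromatic carbon, para to a methoxy group, with sulfur entering where oxygen leaves. For the measured compounds named here, no two measured compounds show a swap of this kind, so there is no measured step to lean on. In this assay the expectation is therefore a change no larger than the usual scatter, with neither direction favoured. Compound 3 may also turn out to give only a limit. The expected step is a number no higher from compound 1 to compound 3 (the limit leaves the size open). For compound 3 the estimated value is 25000 nM, with an expected range from 9000 nM to 60000 nM.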

Compound 3, half-maximal effective concentration: > 25000 nM
Compound 3: no number, only a limit; the forecaster's own chance of this, stated with the estimate: 60%; the middle value sits exactly at the limit.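

In this assay compound 3 gives > 25000 nM as a limit and not a number. No step can be read between compound 1 and compound 3, because compound 1 also gives only a limit: the limit of > 25000 nM in this assay, at which 2 of the 3 values shown sit. As far as these compounds go, whether 1,3-benzothiazol-2-yl in place of 1,3-benzoxazol-2-yl changes the reading at all, and in which direction, stays open.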